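This account rests on a few compounds, and the source may have more. Where it says the series, first, only, none or still open, it means among the compounds named here.

Measured so far:
compound 1, `Oc1ccc(-c2cc(-c3ccc(C(F)(F)F)cc3)cc(-c3cccc(O)c3)n2)cc1`, with 17300 nM in a functional assay on HeLa cells (Homo sapiens) for inhibition; on this read-out higher numbers stand for weaker inhibition and lower numbers for stronger inhibition
compound 2, `Oc1cccc(-c2cc(-c3ccc(OC(F)(F)F)cc3)cc(-c3ccccc3O)n2)c1`, with 20600 nM in this assay

Compound 2 holds the highest of the two numbers in this assay, but compound 1 lies so close that the two values fall within the scatter of each other, so nothing separates them. Compound 3, `Oc1ccc(-c2cc(-c3ccc(OC(F)(F)F)cc3)cc(-c3cccc(O)c3)n2)cc1`, is the next compound to be measured. It differs from compound 2 in a single place: 4-hydroxyphenyl in place of 2-hydroxyphenyl on an aromatic carbon. Going by the values given here, no step between two measured compounds isolates this change, so the expectation rests on the two values alone. Since compound 1, which also carries a 4-hydroxyphenyl group, gives 17300 nM, and compound 2 gives 20600 nM, no step beyond the scatter is expected in this assay. Compound 3 is therefore estimated at 18000 nM, with a range from 7000 nM to 45000 nM, which is a step of a 1.1-fold lower number from compound 2 to compound 3 (0.06 log units; within the scatter) and is expected to be flat within the scatter.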

Compound 3, half-maximal inhibitory concentration: 27800 nM
Estimate against measurement, compound 3: 1.5-fold (0.19 log units) below; the measured number falls inside the stated range.
By their numbers in this assay, from the lowest: compounds 1, 2 and 3 (each within the scatter of the next).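

In this assay, 4-hydroxyphenyl in place of 2-hydroxyphenyl on the aromatic carbon next to the ring nitrogen gives a 1.3-fold higher number from compound 2 to compound 3 (0.13 log units; within the scatter), so this position does not tell the two hydroxyphenyl groups apart on this read-out. The other single change, trifluoromethoxy in place of trifluoromethyl, gives a 1.6-fold higher number from compound 1 to compound 3 (0.21 log units; within the scatter), so that pair of groups is not told apart either when 4-hydroxyphenyl stands at this position. Nothing available accounts for either result.

The compounds shown leave open whether a group such as an aminophenyl or a carboxyphenyl at this position would give a step beyond the scatter. They also leave open whether an amine or a longer chain such as pentafluoroethyl in place of trifluoromethoxy would do so.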